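Trimming the ring substituent of compound 3

The source may hold more compounds than are shown below. What is called first, only, known or untested is meant among the compounds shown, and "the series" means these compounds.

Compound 1 `COC(c1cc(Cl)c2c(c1Cl)C(=O)N(Cc1c(C)cc(C)[nH]c1=O)CC2)C1CCOCC1`: 1460 nM; 9 nM (2 entries) in an assay on cells for inhibition of histone-lysine N-methyltransferase EZH2 (Homo sapiens), read by ELISA, with a stated time of 72 h; on this read-out higher numbers stand for weaker inhibition and lower numbers for stronger inhibition
Compound 2 `Cc1cc(C)c(CN2CCc3c(Cl)cc(C(CO)c4ccon4)c(Cl)c3C2=O)c(=O)[nH]1`: 7960 nM; 273 nM (2 entries) in this assay
Compound 3 `Cc1cc(C)c(CN2CCc3c(Cl)cc([C@H](CO)[C@@H]4CCCO4)c(Cl)c3C2=O)c(=O)[nH]1`: 41 nM in this assay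

Among the measured compounds shown here, compound 3 carries the only single number among the three entries recorded for it in this assay, and that number sits at the strong end of what the set shows. For the measured compounds named here, compound 1 has two entries far apart, (the several entries of compound 1 in this assay, 1460 nM; 9 nM (2 entries)), and compound 2 likewise, (the several entries of compound 2 in this assay, 7960 nM; 273 nM (2 entries)), so the scatter can be large, and the single reading of compound 3 should be read with that in mind.

Compound 4 `Cc1cc(C)c(CN2CCc3c(Cl)cc([C@H](C)CO)c(Cl)c3C2=O)c(=O)[nH]1` has not yet been measured. It differs from compound 3 by a group of 4 heavy atoms (3 carbon, 1 oxygen; no ring) in place of a group of 8 heavy atoms (6 carbon, 2 oxygen; one five-membered non-aromatic ring with 1 hetero atom), on an aromatic carbon. The change removes the five-membered ring and leaves a short 1-(hydroxymethyl)ethyl arm in its place. Going by the values given here, no measured pair in the set isolates this kind of change, so the expectation rests on the general reading that compounds carrying a larger substituent at that aromatic carbon gave the stronger single entries, compound 1 and compound 3 among them, while compound 2 with its flat ring did not.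

Compound 4 is therefore expected to be weaker than compound 3, at an estimated 160 nM with a range from 40 nM to 650 nM. The expected step is a 3.9-fold higher number from compound 3 to compound 4 (0.59 log units; beyond the scatter), a loss likely beyond the usual scatter.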

Compound 4, half-maximal inhibitory concentration: 129 nM
Compound 4: middle estimate off by 1.2-fold (0.09 log units), on the high side; the range from low to high includes it.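

In this assay, among the compounds shown here, taking away the five-membered non-aromatic ring and leaving the 1-(hydroxymethyl)ethyl arm on the aromatic carbon gives a 3.1-fold higher number from compound 3 to compound 4 (0.50 log units; beyond the scatter), the first change at this position that can be read on its own. The step is modest and compound 4 still reads 129 nM, so inhibition at this level does not depend on the ring, although its removal costs a measurable part of the reading. Even so, the step joins two single readings, and entries for one compound in this series can lie far apart: the several entries of compound 1 in this assay, 1460 nM; 9 nM (2 entries)

The compounds shown leave open whether the loss follows from the missing ring itself or from the missing ring oxygen, and a cyclopentyl ring in the same place would separate the two. On these data alone, it also remains open how the arm behaves with the opposite configuration at its stereocentre, or with its hydroxyl replaced by a primary amine or a methoxy group.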